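Removing a methyl from the ring on nitrogen

A few compounds are considered here, and "the series" means these few. Any claim that something is new, unique, unknown or untested is made for them only; others in the source may bear on it.

The shared core carries a hydroxamic acid and a five-membered ring bearing two aromatic rings, one on a nitrogen. Compound 1 `Cc1ccccc1-n1nc(-c2ccccc2)nc1CNc1ccc(C(=O)NO)cc1` has a 2-methylphenyl there, and in a functional assay on MGC-803 cells (Homo sapiens) for antiproliferative activity, read by MTT assay, with a stated time of 72 h (a lower number here means a stronger inhibitor, a higher number a weaker inhibitor), compound 1 gives 12300 nM. Compound 3 `O=C(NO)c1ccc(NCc2nc(-c3ccccc3)nn2-c2cccc(Cl)c2)cc1` gives 13700 nM, so that a 1.1-fold higher number from compound 1 to compound 3 (0.05 log units; within the scatter) places the two compounds within the scatter of each other. Compound 2 `O=C(NO)c1ccc(NCc2nc(-c3ccc(Cl)cc3)nn2-c2ccccc2)cc1`, with a chlorine on the other aromatic ring, gives 5970 nM, a lower number than compound 1 and beyond the scatter. The new compound 4 `O=C(NO)c1ccc(NCc2nc(-c3ccccc3)nn2-c2ccccc2)cc1` differs from compound 1 by one change: hydrogen in place of methyl on an aromatic carbon. Going by the values given here, the only measured step that touches the same ring is the step from compound 1 to compound 3, which stayed within the scatter even with a larger swap. Among the compounds with values here, no step here shows that a change on this ring moves the number much, so compound 4 is expected to stay close to compound 1, with an estimated step of a 1.0-fold lower number from compound 1 to compound 4 (0.01 log units; within the scatter). Compound 4 is therefore estimated at 12000 nM, within a range from 5000 nM to 30000 nM.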

Compound 4, half-maximal inhibitory concentration: 17700 nM
The estimate for compound 4 lay 1.5-fold (0.17 log units) below the measured number, and the stated range covers the measured number.
By their numbers in this assay, from the lowest: compound 2; then compounds 1, 3 and 4 (each within the scatter of the next).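

With the plain phenyl as a reference in this assay, the ring on nitrogen can now be read on its own terms: going from 2-methylphenyl to phenyl gives a 1.4-fold higher number from compound 1 to compound 4 (0.16 log units; within the scatter) and removing the chlorine of the 3-chlorophenyl gives a 1.3-fold higher number from compound 3 to compound 4 (0.11 log units; within the scatter) and so neither group separates from bare phenyl. Going by these compounds alone, removing the chlorine from the other aromatic ring gives a 3.0-fold higher number from compound 2 to compound 4 (0.47 log units; beyond the scatter) and this is the only one of the three steps to compound 4 that lies beyond the scatter. Nothing measured here explains why the two rings differ in this way.

From the compounds shown here alone, it remains open whether an amine or a carboxylic acid on the ring on nitrogen would move the number. Going by these compounds, it also remains open whether a methyl on the other aromatic ring would match the effect of its chlorine.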